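A few compounds are considered here, and "the series" means these few. Any claim that something is new, unique, unknown or untested is made for them only; others in the source may bear on it.

Measured so far, in a functional assay on PC-3 cells (Homo sapiens) for cytotoxicity, read by MTT assay, with a stated time of 72 h; a higher number here means a weaker inhibitor, a lower number a stronger inhibitor:
- compound 1, `CCCOCNc1n[n+]([O-])c2cc(OC)ccc2[n+]1[O-]`: 10600 nM
- compound 2, `[O-][n+]1nc(NCOC2CCCCC2)[n+]([O-])c2ccccc21`: 6670 nM
- compound 3, `O=[N+]([O-])c1cccc(COCNc2n[n+]([O-])c3ccccc3[n+]2[O-])c1`: > 100000 nM

For compound 3 the entry in this assay is a limit of the assay, not a number, as in the limit of > 100000 nM in this assay, at which 1 of the 3 values shown sits. Among the two numbers, compound 2 holds the lowest; compound 1 is nearest, and the gap between them lies within the scatter, so no order between the two is claimed.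

Compound 4, `COCNc1n[n+]([O-])c2ccccc2[n+]1[O-]`, follows from compound 2 by methyl in place of cyclohexyl on an oxygen on a saturated carbon. Within the data shown here, no measured step covers this kind of change. The step expected in this assay is a 3.0-fold higher number from compound 2 to compound 4 (0.48 log units; beyond the scatter), towards a higher number. Compound 4 is estimated at 20000 nM, in the range 7000 nM to 60000 nM.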

Compound 4, half-maximal inhibitory concentration: 4270 nM
Beside the measured number, compound 4's estimate is 4.7-fold (0.67 log units) above it, and the stated range ends above it.
By their numbers in this assay, from the lowest: compounds 4, 2 and 1 (each within the scatter of the next, the first and the last beyond it). At a limit, above all of these: compound 3.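

In this assay, methyl in place of cyclohexyl on this oxygen gives a 1.6-fold lower number from compound 2 to compound 4 (0.19 log units; within the scatter). The two numbers cannot be told apart, so at this position the ring of cyclohexyl is not required for a number in this range, and a group as small as methyl serves equally. Nothing available bears on the reason for this result. Still open, from the compounds shown here alone, is whether an amine or a carboxylic acid carried on a longer chain at this oxygen would keep the number in this range. Also open, going by these compounds, is whether methyl and cyclohexyl stay level on the methoxy-bearing core of compound 1.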